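This account rests on a few compounds, and the source may have more. Where it says the series, first, only, none or still open, it means among the compounds named here.

The three measured compounds, with their values in a functional assay on MCF7 cells (Homo sapiens) for cytotoxicity, read by sulforhodamine B assay, with a stated time of 48 h; on this read-out higher numbers stand for weaker inhibition and lower numbers for stronger inhibition:

Compound 1, `COc1ccc(/C=C/C(=O)/C=C/C2=C(C)CCCC2(C)C)cc1`: 19600 nM
Compound 2, `COc1ccc(/C=C/C(=O)/C=C/C2=C(C)CCCC2(C)C)cc1OC`: 35600 nM
Compound 3, `CC1=C(/C=C/C(=O)/C=C/C=C/c2ccccc2)C(C)(C)CCC1`: 46700 nM

Compound 4, `COc1ccccc1/C=C/C=C/C(=O)/C=C/C1=C(C)CCCC1(C)C`, has not yet been measured in this assay. It differs from compound 3 by methoxy in place of hydrogen on an aromatic carbon. The same kind of change is seen between two measured compounds: compound 2 differs from compound 1 by methoxy in place of hydrogen on an aromatic carbon, and that change gave a 1.8-fold higher number from compound 1 to compound 2 (0.26 log units; within the scatter). The surroundings of the place are not the same in the two pairs: in compound 2 the entering methoxy sits ortho to a methoxy group and meta to a large group, while in compound 4 it sits ortho to a large group. The difference between the core of compound 1 and the core of compound 3 is not broken down here. What the values show is that compound 3 and compound 2 lie within the usual scatter of one another, while the number for compound 3 is higher than that for compound 1 by a gap beyond the scatter.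

For the measured compounds named here, on the strength of the one measured instance of this change, compound 4 is expected to stay close to compound 3, with an estimated step of a 1.5-fold higher number from compound 3 to compound 4 (0.18 log units; within the scatter) in this assay, because a 1.8-fold higher number from compound 1 to compound 2 (0.26 log units; within the scatter) was small. Compound 4 is therefore estimated at 70000 nM, with a range from 30000 nM to 160000 nM.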

Compound 4, half-maximal inhibitory concentration: 55400 nM
For compound 4 the middle estimate is 1.3-fold (0.10 log units) above the measured one; the range from low to high includes it.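

In this assay, methoxy in place of hydrogen on an aromatic carbon gave a 1.2-fold higher number from compound 3 to compound 4 (0.07 log units; within the scatter), so on this read-out compound 4 cannot be told apart from compound 3. Set beside the earlier instance, the change looks alike on the two cores, and the two steps cannot be told apart from each other: the same change on two cores in this assay, a 1.8-fold higher number (0.26 log units; within the scatter) from compound 1 to compound 2 and a 1.2-fold higher number (0.07 log units; within the scatter) from compound 3 to compound 4, 1.5-fold (0.19 log units) apart, within the scatter of two such steps. For the compounds shown here, this supports carrying the change between these two cores as a small step, but it rests on only two pairs, neither step stands clear of the scatter, and the surroundings of the entering methoxy are not the same in the two pairs, since in compound 4 it sits ortho to a large group, so it shows neither a real effect of methoxy nor how the change would behave on any further core.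

The compounds shown leave open whether another group on the aromatic ring, such as an amine, a carboxylic acid or a fluorine atom, would move the number beyond the scatter where methoxy did not. They also leave open which part of the difference between the core of compound 1 and the core of compound 3 matters, and whether a longer chain would change the picture.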